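From compound 1 to compound 4: one group exchanged

This account rests on a few compounds, and the source may have more. Where it says the series, first, only, none or still open, it means among the compounds named here.

In an ADME assay on microsomes from liver (Mus musculus) for metabolic stability, read by LC-MS, with a stated time of 30 min, tested at 1 uM (a higher number here means that more of the compound is left, a lower number that less of the compound is left), compound 1 (`CC(=O)N1CCN(C(=O)[C@@H]2CC[C@@H](C)N2C(=O)C2=C(C(C)C)N3C(=N[C@@](C)(c4ccc(Cl)cc4)[C@H]3c3ccc(Cl)cc3)S2)CC1`) gives 13%. Compound 3 (`CC[C@@H]1CC[C@@H](C(=O)N2CCOCC2)N1C(=O)C1=C(C(C)C)N2C(=N[C@@](C)(c3ccc(Cl)cc3)[C@H]2c2ccc(Cl)cc2)S1`) gives 6%, which lies within the scatter of compound 1, while compound 2 (`CC[C@@H]1CC[C@@H](C(=O)N2CCN(C(C)=O)CC2)N1C(=O)C1=C(C(C)C)N2C(=N[C@@](C)(c3ccc(Cl)cc3)[C@H]2c2ccc(Cl)cc2)S1`) gives 38%, clearly more than either. Compound 4 (`CC(C)C1=C(C(=O)N2[C@H](C)CC[C@H]2C(=O)N2CCN(C)C(C)(C)C2)SC2=N[C@@](C)(c3ccc(Cl)cc3)[C@@H](c3ccc(Cl)cc3)N21`) is not yet measured, and it differs from compound 1 in one group on a carbonyl carbon: a group of 9 heavy atoms (7 carbon, 2 nitrogen; one six-membered non-aromatic ring with 2 hetero atoms) in place of a group of 9 heavy atoms (6 carbon, 2 nitrogen, 1 oxygen; one six-membered non-aromatic ring with 2 hetero atoms), on a carbonyl carbon.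

The closest guide is a number 32 percentage points lower from compound 2 to compound 3 (beyond the scatter), a large step in which morpholin-4-yl replaced 4-acetylpiperazin-1-yl on that carbonyl carbon. It shows that a swap at this place can matter, but it lands at the low end, with compound 3 at 6%. The other step, a number 25 percentage points higher from compound 1 to compound 2 (beyond the scatter), is modest and comes from a change elsewhere, so it says little here. For the measured compounds named here, no measured compound carries the entering group, and compound 1 at 13% has little room to fall. The expected outcome is therefore no step beyond the scatter, with an estimate of a number 1 percentage points lower from compound 1 to compound 4 (within the scatter). For compound 4 the estimated value is 12%, with an expected range from 3% to 35%.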

Compound 4, percent of the compound remaining: 84%
The estimate for compound 4 lay 72 percentage points below the measured number; the measured number lies above the stated range.
By their numbers in this assay, from the lowest: compounds 3 and 1 (each within the scatter of the next); then compound 2; then compound 4.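

In this assay, for the compounds shown here, the exchange on this carbonyl carbon gives a number 71 percentage points higher from compound 1 to compound 4 (beyond the scatter), so a swap at this place can raise the number sharply; the only earlier swap here, a number 32 percentage points lower from compound 2 to compound 3 (beyond the scatter), went downward. The leaving and entering groups match in heavy-atom count, ring size, hydrogen-bond donors and acceptors, and net charge, so none of these counts separates them, and a large change in this read-out can arise without any difference in them. Nothing measured here accounts for the gain.

Going by these compounds, it remains open which feature of the entering group matters, and a plain 4-methylpiperazin-1-yl group on the same carbonyl carbon would help to narrow this down. On these data alone, it is also open whether the entering group would give a similar result when paired with the change from compound 1 to compound 2.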